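Alkyl on the Aromatic Nitrogen: Maximal Response Notes

A few compounds are considered here, and "the series" means these few. Any claim that something is new, unique, unknown or untested is made for them only; others in the source may bear on it.

Measured so far:
- compound 1, `CC(C)n1ncnc1-c1ccccc1NCC1=NCCN1`, in a functional assay with Alpha-1B adrenergic receptor (Homo sapiens) as the target, read by calcium flux (on this read-out higher numbers stand for larger maximal responses and lower numbers for smaller maximal responses), compound 1 gives 0%
- compound 2, `CCCn1nccc1-c1ccccc1NCC1=NCCN1`, in this assay compound 2 gives 0%
- compound 3, `CC(C)n1nccc1-c1ccccc1NCC1=NCCN1`, in this assay compound 3 gives 0%

Compound 3 stands level with compound 1 and compound 2 at the digits shown; none of the three produces a maximal response in this assay distinguishable from the control. Compound 1 and compound 2 show the same values as compound 3, so no ordering among them can be drawn.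

Compound 4, `CCn1nccc1-c1ccccc1NCC1=NCCN1`, differs from compound 3 by hydrogen in place of methyl on a saturated chain carbon bound to an aromatic nitrogen and a saturated chain carbon.

Among the measured compounds shown here, one measured step bears on this change, as it alters the same alkyl group on the aromatic nitrogen: no change at the digits printed from compound 2 to compound 3 (within the scatter). That exchange of one chain for another at this position left the maximal response where it was. Shortening the chain further in compound 4 is therefore expected to give no step beyond the scatter, no change at the digits printed from compound 3 to compound 4 (within the scatter), in this assay.

For compound 4 the estimated value in this assay is 0%, with an expected range from 0% to 10%. Whether any alkyl at this position would raise the response is not answered by these three compounds.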

Compound 4, largest response reached (reported as maximal response), in percent of the reference or control that the assay uses: 0%
Estimate against measurement, compound 4: no gap at the digits printed; measured number inside the range.
By their numbers in this assay, from the lowest: compounds 1, 2, 3 and 4 (each within the scatter of the next).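

Hydrogen in place of methyl on a saturated chain carbon bound to an aromatic nitrogen and a saturated chain carbon, the change from isopropyl to ethyl, leaves the maximal response in this assay unmoved (no change at the digits printed from compound 3 to compound 4 (within the scatter)). The straight chains agree as well, with hydrogen in place of methyl on a saturated chain carbon, two bonds along the chain from an aromatic nitrogen (no change at the digits printed from compound 2 to compound 4 (within the scatter)), so the earlier propyl and isopropyl comparison now extends to ethyl, and the three alkyl groups at this position read alike in this assay. No measurement in hand offers an explanation for this flat read-out.

Ethyl, propyl and isopropyl span only a narrow range of small alkyl groups, so it remains open whether a longer chain such as hexyl, a benzyl group, or a chain carrying an amine or a carboxylic acid on the aromatic nitrogen would give a maximal response above the level of these compounds. With every value in this set at the same level, the series also gives no starting point for ranking groups at this position, and any such ranking would need a compound with a response clearly beyond the scatter.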